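The compounds below may be only part of what the source reports. "The series", "measured", "known", "first", "only" and "open" are said of these compounds alone.

Compound 2 `Cc1nn(-c2ccccc2)c(Oc2ccc(Cl)cc2)c1/C=N/OCc1ccc(C(=O)OC(C)(C)C)cc1` is the point of departure. In a functional assay on MKN-45 cells (Homo sapiens) for antiproliferative activity, tested at 1 uM (on this read-out higher numbers stand for more inhibition at the one concentration tested (going by the name of the read-out) and lower numbers for less inhibition), compound 2 gives -9.9%. Compound 1 `Cc1c(CO/N=C/c2c(-c3ccccc3)nn(-c3ccccc3)c2Oc2ccc(Cl)cc2)cccc1-c1ccccc1` gives -15% and compound 3 `CCOC(=O)c1ccc(CO/N=C/c2c(C)nn(-c3ccccc3)c2Oc2ccc(Cl)cc2)cc1` gives -17.8%; both numbers sit within the scatter of the number for compound 2. Among the compounds with values here, the only step measured between neighbours, a number 7.9 percentage points lower from compound 2 to compound 3 (within the scatter), changes the ester and lies within the scatter. Compound 4 `CC(C)c1nn(-c2ccccc2)c(Oc2ccc(Cl)cc2)c1/C=N/OCc1ccc(C(=O)OC(C)(C)C)cc1` differs from compound 2 by isopropyl in place of methyl on an aromatic carbon. Within the data shown here, no measured step touches this position, so nothing among the three compounds points to a change beyond the scatter. Compound 4 is therefore expected to give about -10%, with a likely range from -25% to 5%; the step of a number 0.1 percentage points lower from compound 2 to compound 4 (within the scatter) is an estimate that assumes no effect beyond the scatter.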

Compound 4, a percentage reported as inhibition, at one concentration (the size of the read-out at that concentration, not a potency): -27%
The estimate for compound 4 lay 17 percentage points above the measured number; measured number below the stated range.
By their numbers in this assay, from the lowest: compounds 4, 3, 1 and 2 (each within the scatter of the next, the first and the last beyond it).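

In this assay, isopropyl in place of methyl on this aromatic carbon gives a number 17.1 percentage points lower from compound 2 to compound 4 (beyond the scatter), the only step among these compounds that goes beyond the scatter. The position therefore responds to a change of group, here towards less inhibition at the one concentration tested, which the ester change had not shown. No available evidence accounts for this step.

The compounds shown leave open whether ethyl or an amine on this carbon would also lower the number. They also leave open whether the step would hold with an ethyl ester in place of the tert-butyl ester.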